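Pyrazole amide pair: acetyl to cyclobutylcarbonyl on a second core

The compounds below may be only part of what the source reports. "The series", "measured", "known", "first", "only" and "open" are said of these compounds alone.

Compound 1 `CC(=O)n1nc(C)c(-c2ccc(Cl)c(Cl)c2)c1N` and compound 2 `Cc1nn(C(=O)C2CCC2)c(N)c1-c1ccc(Cl)c(Cl)c1` share one core and differ in one place; in an assay on Sf9 cells for inhibition of mitogen-activated protein kinase kinase kinase 14 (Homo sapiens), read by ADP-Glo, with a stated time of 60 min (on this read-out higher numbers stand for weaker inhibition and lower numbers for stronger inhibition), compound 1 gives 8400 nM and compound 2 gives 2900 nM. The change between them is cyclobutyl in place of methyl on a carbonyl carbon and it brought a 2.9-fold lower number from compound 1 to compound 2 (0.46 log units; beyond the scatter).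

Compound 3 `CC(=O)n1nc(N)c(-c2ccc(Cl)c(Cl)c2)c1C` has the same atoms as compound 1 joined differently; the difference between the two cores is not broken down here. In this assay compound 3 reached only a limit of the assay, > 100000 nM, and this is the point named in the limit of > 100000 nM in this assay, at which 1 of the 3 values shown sits.

Compound 4 `Cc1c(-c2ccc(Cl)c(Cl)c2)c(N)nn1C(=O)C1CCC1` is to compound 3 what compound 2 is to compound 1: the difference is cyclobutyl in place of methyl on a carbonyl carbon, the same change as before, at a place described in the same words. Among the measured compounds shown here, the only guide to its size on the core of compound 3 is the earlier pair, where compound 1 to compound 2 gave a 2.9-fold lower number from compound 1 to compound 2 (0.46 log units; beyond the scatter). Carried over to compound 3, whose value in this assay is a limit rather than a number, the expected step is a number no higher from compound 3 to compound 4 (the limit leaves the size open), and a step of that size starting from a limit leaves a fair chance that compound 4 also reports only a limit. On that basis compound 4 is estimated at 100000 nM in this assay, with the range 30000 nM to 300000 nM expected to hold most repeats.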

Compound 4, half-maximal inhibitory concentration: > 100000 nM
Compound 4: a limit, no number; the forecaster's own chance of this, stated with the estimate: 55%; the middle value sits exactly at the limit.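

In this assay compound 4 gives > 100000 nM as a limit of the assay, not a number. Compound 3 also stands at a limit, so no step can be read between compound 3 and compound 4. From the compounds shown here alone, whether cyclobutyl in place of methyl on a carbonyl carbon shifts the value on the core of compound 3, as it did on the core of compound 1, stays open.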